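Working notes: methyl to hydroxy, compound 3 to compound 4

The compounds below may be only part of what the source reports. "The series", "measured", "known", "first", "only" and "open" are said of these compounds alone.

Measured so far in a functional assay on NCI-H460 cells (Homo sapiens) for cytotoxicity, read by sulforhodamine B assay (on this read-out higher numbers stand for lower toxicity in this test and lower numbers for higher toxicity in this test), with these results:
compound 1 `CC1=CC[C@@H]([C@@](C)(O)CCCC(C)(C)NC=S)CC1` gives > 100000 nM as a limit
compound 2 `CC1=CC[C@@H]([C@@](C)(O)CCCC(C)(C)NC(=S)N/N=C\c2ccccc2)CC1` gives > 100000 nM as a limit
compound 3 `CC1=CC[C@@H]([C@@](C)(O)CCCC(C)(C)NC(=S)N/N=C\c2ccc(C)cc2)CC1` gives > 100000 nM as a limit

In this assay compound 3 stands at > 100000 nM and this is a limit, not a number. Going by the values given here, the evidence so far is the limit of > 100000 nM in this assay, at which 3 of the 3 values shown sit, and no compound has yet given a number. The change to compound 4 `CC1=CC[C@@H]([C@@](C)(O)CCCC(C)(C)NC(=S)N/N=C\c2ccc(O)cc2)CC1` is hydroxy in place of methyl on an aromatic carbon and puts hydroxy in place of methyl on an aromatic carbon. Among the compounds with values here, two measured steps bear on it. One is a step that the two limits leave unreadable from compound 2 to compound 3 and it also alters a group on an aromatic carbon. The other is a step that the two limits leave unreadable from compound 1 to compound 2 and it adds the aromatic ring. Neither has a readable size, so neither gives a direction. The expectation rests on compound 3, whose value of > 100000 nM is again a limit. The step expected is a number no higher from compound 3 to compound 4 (the limit leaves the size open) and it is an estimate only, with no change beyond the usual scatter foreseen. The value expected for compound 4 is 100000 nM with an estimated range from 30000 nM to 200000 nM and a report as a limit is likely.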

Compound 4, concentration lethal to 50% of the cells: > 100000 nM
Compound 4 gave a limit, no number; the forecaster's own chance of this, stated with the estimate: 80%; the middle value lies on the limit itself.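

Going by these compounds alone, no step to compound 4 can be read from compound 2 or from compound 3: all three values are limits, not numbers. The compounds shown leave open whether any change to this series would give a number rather than a limit: the limit of > 100000 nM in this assay, at which 4 of the 4 values shown sit.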